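A few compounds are considered here, and "the series" means these few. Any claim that something is new, unique, unknown or untested is made for them only; others in the source may bear on it.

Within the data shown here, compound 3 `CC(C)(C)c1ccc(C(=O)N2CCC3(CC2)C(=O)N(CC(=O)NCNS(C)(=O)=O)CN3c2ccccc2)cc1` gives 3200 nM in an assay on HEK293 cells for displacement of a labelled ligand from NPC1-like intracellular cholesterol transporter 1 (Homo sapiens) (on this read-out higher numbers stand for weaker inhibition and lower numbers for stronger inhibition), the second highest of the three numbers measured so far. Compound 1 `CC(C)(C)c1ccc(C(=O)N2CCC3(CC2)C(=O)N(CC(=O)NCCO)CN3c2ccccc2)cc1` gives 1000 nM and compound 2 `CC1CCCN(C(=O)CN2CN(c3ccccc3)C3(CCN(C(=O)c4ccc(C(C)(C)C)cc4)CC3)C2=O)C1` gives 12000 nM. The move to compound 4 `CC(C)(C)c1ccc(C(=O)N2CCC3(CC2)C(=O)N(CC(=O)NCCCCCO)CN3c2ccccc2)cc1` is 4-hydroxybutyl in place of methanesulfonamido on a saturated chain carbon bound to an amide-type nitrogen. The measured step that bears most on it is a 3.2-fold higher number from compound 1 to compound 3 (0.51 log units; beyond the scatter), which is close to the reverse of the change made here, while a 12-fold higher number from compound 1 to compound 2 (1.08 log units; beyond the scatter) and a 3.8-fold lower number from compound 2 to compound 3 (0.57 log units; beyond the scatter) alter a different part of the molecule and say less. Because of a 3.2-fold higher number from compound 1 to compound 3 (0.51 log units; beyond the scatter) the step for compound 4 is estimated as a 2.7-fold lower number from compound 3 to compound 4 (0.43 log units; beyond the scatter), a modest move to a lower number. Compound 4 is therefore expected to give 1200 nM in this assay, with a range from 400 nM to 4000 nM.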

Compound 4, half-maximal inhibitory concentration: 9400 nM
The estimate for compound 4 lay 7.8-fold (0.89 log units) below the measured number; measured number above the stated range.
By their numbers in this assay, from the lowest: compound 1; then compound 3; then compounds 4 and 2 (each within the scatter of the next).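

On the carbonyl side chain, a hydroxy at the chain end does not by itself hold the number of compound 1: in this assay, moving it further out, with 3-hydroxypropyl in place of hydroxy, gives a clear loss (a 9.4-fold higher number from compound 1 to compound 4 (0.97 log units; beyond the scatter)). The same chain also does worse than the methanesulfonamido chain (a 2.9-fold higher number from compound 3 to compound 4 (0.47 log units; beyond the scatter)). It cannot be told apart from the 3-methylpiperidin-1-yl amide (a 1.3-fold lower number from compound 2 to compound 4 (0.11 log units; within the scatter)).

Open, going by these compounds, is where between (2-hydroxyethyl)amino and (5-hydroxypentyl)amino the number rises, which a 3-hydroxypropyl chain on that nitrogen would test, and how an amine or carboxylic acid at the chain end would compare. No measurement here gives a reason for these steps.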